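Removing the methoxymethyl group from compound 2

The source may report more compounds than this note shows. Statements on the series, on what has been measured and on what is new or still open speak of the compounds shown alone.

In a functional assay on MCF7 cells (Homo sapiens) for cytotoxicity, read by MTT assay (a higher number here means a weaker inhibitor, a lower number a stronger inhibitor), compound 1 (`COc1ccc([C@@H]2C[C@@H]2c2cc(OC)c(OC)c(OC)c2)cc1O`) gives 102 nM and compound 2 (`COCOc1cc(C#Cc2cc(OC)c(OC)c(OC)c2)ccc1OC`) gives 25600 nM as the higher of the two numbers, a gap beyond the scatter. Compound 3 (`COc1ccc(C#Cc2cc(OC)c(OC)c(OC)c2)cc1O`) departs from compound 2 by hydrogen in place of methoxymethyl on an oxygen on an aromatic ring with hydrogen in place of methoxymethyl on an oxygen on an aromatic ring. For the measured compounds named here, compound 1 also carries a hydroxy, on a different core, and reads 102 nM but no measured step isolates this change. A large move toward a lower number, beyond the scatter, is expected (a 17-fold lower number from compound 2 to compound 3 (1.23 log units; beyond the scatter)). For compound 3 the estimate is 1500 nM (range 150 nM to 15000 nM).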

Compound 3, half-maximal inhibitory concentration: 1640 nM
Compound 3: middle estimate off by 1.1-fold (0.04 log units), on the low side, and the stated range covers the measured number.
By their numbers in this assay, from the lowest: compound 1; then compound 3; then compound 2.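

In this assay, for the compounds shown here, going from methoxymethoxy to hydroxy on the aromatic ring gives a 16-fold lower number from compound 2 to compound 3 (1.19 log units; beyond the scatter), the first single change that can be read directly. On this core, the free hydroxy gives the lower number, and this oxygen is a position where the group clearly affects the read-out. Nothing measured here bears on why the step is this large.

On these data alone, it remains open whether an amine in place of the hydroxy would keep this gain. As far as these compounds go, whether the methoxymethyl group would cost as much on the core of compound 1 is also open.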